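Permeability notes: from compound 1 to compound 4

The compounds below may be only part of what the source reports. "The series", "measured", "known", "first", "only" and "open" are said of these compounds alone.

Measured in an ADME assay for permeability, using PAMPA, with a stated time of 30 min, at pH 7.4; a lower number here means that the compound crosses the layer more slowly, a higher number that the compound crosses the layer faster:
- compound 1 `COc1ccc(Cn2c(-c3ccccc3)c(-c3ccccc3)c3c(=N)n(C4CCOCC4)cnc32)cc1` gives "nd" (no result reported)
- compound 2 `COc1ccc(Cn2c(-c3ccccc3)c(-c3ccccc3)c3c(=N)n([C@H]4CC[C@H](O)CC4)cnc32)cc1` gives > 1000 10^-6 cm/s (a limit, not a number)
- compound 3 `COc1ccc(Cn2c(-c3ccccc3)c(-c3ccccc3)c3c(=N)n(CC4CCCO4)cnc32)cc1` gives > 1000 10^-6 cm/s (a limit, not a number)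

Compound 1 has no number to start from: its entry is "nd" (no result reported). The nearest evidence is the limit of > 1000 10^-6 cm/s in this assay, at which 2 of the 3 values shown sit.

Compound 4 `N=c1c2c(-c3ccccc3)c(-c3ccccc3)n(CC3CC3)c2ncn1C1CCOCC1` is the next to be read in this assay. It differs from compound 1 by cyclopropyl in place of 4-methoxyphenyl on a saturated chain carbon bound to an aromatic nitrogen. In words, cyclopropyl stands in place of 4-methoxyphenyl on a saturated chain carbon bound to an aromatic nitrogen, so that 4-methoxybenzyl becomes cyclopropylmethyl.

Within the data shown here, no measured step covers this change. Among the measured compounds shown here, the one step available, a step that the two limits leave unreadable from compound 2 to compound 3, leaves the 4-methoxybenzyl group untouched and gives no size to carry over. With no starting value and no readable step, no step size or direction can be expected in this assay. For the measured compounds named here, the working expectation is only that compound 4 will fall near the limit reached by the two measured analogues, and it may well be reported as a limit too.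

The estimated value for compound 4 is 1000 10^-6 cm/s, with an expected range of 500 10^-6 cm/s to 2000 10^-6 cm/s.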

Compound 4, apparent permeability: > 1000 10^-6 cm/s
Compound 4 gave a limit, no number; the forecaster's own chance of this, stated with the estimate: 70%; the middle value sits exactly at the limit.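

In this assay compound 4 gives > 1000 10^-6 cm/s, a limit and not a number. Compound 1 gives "nd" (no result reported), so no step can be read from compound 1 to compound 4. The compounds shown leave open whether cyclopropyl in place of 4-methoxyphenyl shifts the read-out at all, as the values stop at one limit: the limit of > 1000 10^-6 cm/s in this assay, at which 3 of the 4 values shown sit.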